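Moving the ring substituent in a urea series

A few compounds are considered here, and "the series" means these few. Any claim that something is new, unique, unknown or untested is made for them only; others in the source may bear on it.

Measured so far:
compound 1, `CC(C)c1cccc(C(C)C)c1NC(=O)NCC1(c2cccs2)CCCC1`, 12 nM
compound 2, `COc1ccccc1NC(=O)NCC1(c2ccccc2)CCCCC1`, 270 nM
compound 3, `CC(C)c1ccccc1NC(=O)NCC1(c2ccccc2)CCCCC1`, 390 nM

The read-out throughout is an assay on microsomes from intestine for inhibition of acyl-CoA:cholesterol acyltransferase (Oryctolagus cuniculus); on this read-out higher numbers stand for weaker inhibition and lower numbers for stronger inhibition. Compound 2 stands second highest of the three numbers: its nearest neighbour is compound 3, reached by a 1.4-fold higher number from compound 2 to compound 3 (0.16 log units; within the scatter), while compound 1, which gives 12 nM, lies far from it, a gap that is beyond the scatter. Among the compounds with values here, compound 1, however, differs from compound 2 in several places at once, so no single step can be drawn between them.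

The new compound is compound 4, `Cc1ccc(NC(=O)NCC2(c3ccccc3)CCCCC2)cc1`. It is obtained from compound 2 by 4-methylphenyl in place of 2-methoxyphenyl on an amide-type nitrogen. Within the data shown here, the only measured step that bears on this change is the one from compound 2 to compound 3, which also altered the group on the aromatic ring attached to the urea nitrogen and stayed within the scatter. Among the measured compounds shown here, that step kept a group on the same ring carbon; compound 4 instead carries a smaller group on a different ring carbon, and no measured pair covers such a move. With the nearest comparison showing little effect but the change itself unprecedented here, a modest weakening is expected, so this assay for compound 4 is estimated to move by a 3.0-fold higher number from compound 2 to compound 4 (0.47 log units; beyond the scatter). The estimate for compound 4 is 800 nM, with a range from 250 nM to 3000 nM.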

Compound 4, half-maximal inhibitory concentration: 4500 nM
The estimate for compound 4 lay 5.6-fold (0.75 log units) below the measured number; measured number outside the range, above it.
By their numbers in this assay, from the lowest: compound 1; then compounds 2 and 3 (each within the scatter of the next); then compound 4.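

In this assay, the swap of 2-methoxyphenyl for 4-methylphenyl on the amide-type nitrogen gives a 17-fold higher number from compound 2 to compound 4 (1.22 log units; beyond the scatter), a large weakening, whereas the earlier step of a 1.4-fold higher number from compound 2 to compound 3 (0.16 log units; within the scatter) stayed within the scatter. The earlier pair alone could suggest that the aromatic group on this nitrogen tolerates change, but this new step shows that at least one such change costs much of the inhibition, and it alters two things at once: the group itself and the ring carbon that carries it. Nothing measured here gives a reason for this loss.

The compounds shown leave open whether the loss follows the new methyl group or the new ring carbon, a question that 2-methylphenyl and 4-methoxyphenyl on the same nitrogen would help to separate. Also open, going by these compounds, is how a plain phenyl, with no substituent on the ring, would compare with compound 2 and compound 4, and how other groups on that same ring carbon, such as an amine or a carboxylic acid, would behave.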